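One Methyl, Two Cores: What Compound 4 Might Give

The compounds below may be only part of what the source reports. "The series", "measured", "known", "first", "only" and "open" are said of these compounds alone.

Compound 1, `CC1CCC(=O)N1CC#CCn1ccnc1`: in a functional assay on the whole organism for agonist activity, with Mus musculus as the target (on this read-out lower numbers stand for an effect already at smaller amounts and higher numbers for an effect only at larger amounts of compound), compound 1 gives > 100 mg/kg, which is a limit of the assay and not a number.
Compound 2, `Cc1cncn1CC#CCN1C(=O)CCC1C`: in this assay compound 2 gives > 100 mg/kg, again only a limit.
Compound 3, `CN1CCN(CC#CCn2ccnc2)C1=O`: in this assay compound 3 gives 1.4 mg/kg.

The change from compound 1 to compound 2 is methyl in place of hydrogen on an aromatic carbon. Its size, a step that the two limits leave unreadable from compound 1 to compound 2, stays unreadable due to the limit of > 100 mg/kg in this assay, at which 2 of the 3 values shown sit. The difference between the core of compound 1 and that of compound 3 is not broken down here. Compound 4, `Cc1cncn1CC#CCN1CCN(C)C1=O`, awaits measurement in this assay; it differs from compound 3 by methyl in place of hydrogen on an aromatic carbon, the same change as between compound 1 and compound 2. Going by the values given here, no measured step shows how large that change is, so the expectation rests on compound 3 alone with 1.4 mg/kg. The step from compound 3 to compound 4 is estimated as a 1.1-fold higher number from compound 3 to compound 4 (0.06 log units; within the scatter). Compound 4 is expected at 1.6 mg/kg, between 0.5 mg/kg and 6 mg/kg.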

Compound 4, dose for half-maximal effect: 14 mg/kg
Compound 4: middle estimate off by 8.8-fold (0.94 log units), on the low side; the measured number lies above the stated range.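

In this assay, methyl in place of hydrogen on an aromatic carbon gives a 10-fold higher number from compound 3 to compound 4 (1.00 log units; beyond the scatter), so in the core of compound 3 this change moves the effect to larger amounts of compound. This is the only readable size for the change, and it comes from a single pair, so it sets no rule for the series. Whether the step carries over to the core of compound 1 stays unknown, because the pair in that core cannot be read and gives no size to compare: the limit of > 100 mg/kg in this assay, at which 2 of the 4 values shown sit.

The compounds shown leave open how an ethyl group, an amine or a carboxylic acid on that aromatic carbon would read in this assay. They also leave open whether the step seen with methyl would hold in any third core.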